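The source may hold more compounds than are shown below. What is called first, only, known or untested is meant among the compounds shown, and "the series" means these compounds.

In a functional assay on SK-OV-3 cells (Homo sapiens) for cytotoxicity (a lower number here means that less compound is needed, a higher number that more compound is needed for the effect), the measured compounds stand as follows:
compound 1 `C=CCCCCCC#CC#CC(O)CC(C)=O` gives 3.85 ug/mL;
compound 2 `C=CCCCCCCCC#CC#CC(O)CC(C)=O` gives 3.34 ug/mL;
compound 3 `C=CCCCCCC#CC#CCOCCO` gives 17.9 ug/mL.

Compound 2 has the lowest of these three numbers, but compound 1 lies within the scatter of it, and the step of a 1.2-fold lower number from compound 1 to compound 2 (0.06 log units; within the scatter) is too small to count. Compound 3 gives a number well beyond the scatter above compound 2. Compound 4 `C=CCCCCCCCC#CC#CCOCC(=O)O` is not yet measured; it differs from compound 2 by (carboxymethoxy)methyl in place of 2-acetyl-1-hydroxyethyl on a triple-bonded carbon. Within the data shown here, no measured step covers this exchange: the step of a 1.2-fold lower number from compound 1 to compound 2 (0.06 log units; within the scatter) concerns the other end of the chain. The values of compound 2 and compound 3 show that changing this end of the molecule to an ether-bearing chain went with a clearly higher number. Compound 4 is therefore expected to give about 20 ug/mL, within 8 ug/mL to 50 ug/mL. That estimate corresponds to an expected step of a 6.0-fold higher number from compound 2 to compound 4 (0.78 log units; beyond the scatter).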

Compound 4, concentration for half-maximal effect: 4.88 ug/mL
Compound 4: middle estimate off by 4.1-fold (0.61 log units), on the high side; the measured number lies below the stated range.
By their numbers in this assay, from the lowest: compounds 2, 1 and 4 (each within the scatter of the next); then compound 3.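

At the triple-bonded carbon in this assay, the exchange of 2-acetyl-1-hydroxyethyl for (carboxymethoxy)methyl gives a 1.5-fold higher number from compound 2 to compound 4 (0.16 log units; within the scatter), so this position accepts at least this one other group. An ether-bearing group therefore does not always go with a high number, although compound 3 , which also carries one, gives 17.9 ug/mL in a shorter-chain molecule. No available evidence explains this result. Compound 3 and compound 4 differ in more than one place, so their values cannot be compared directly. On these data alone, whether an amine or a longer chain at this position would also be accepted remains open.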